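Half-life series: phenyl for tert-butoxycarbonyl at the side chain

The compounds below may be only part of what the source reports. "The series", "measured", "known", "first", "only" and "open" are said of these compounds alone.

Going by the values given here, compound 3 `CC(C)(C)OC(=O)[C@H](O)[C@H]1C(=O)N2C(C(=O)O)=C(C(C)(C)C)O[C@H]12` holds the highest half-life of the three measured members: in an ADME assay, in phosphate buffer, at 28 degrees C, at pH 7.0 (on this read-out lower numbers stand for a shorter-lived compound and higher numbers for a longer-lived compound), compound 3 gives 10.7 h. Compound 1 `CC(C)(C)C1=C(C(=O)O)N2C(=O)[C@H](CO)[C@H]2O1` is nearest, giving 5 h in this assay, and compound 2 `CC(C)(C)C1=C(C(=O)O)N2C(=O)[C@H]([C@H](O)c3ccccc3)[C@@H]2O1` is furthest, giving 0.5 h. Among the compounds with values here, the single one-point step recorded, a 2.1-fold higher number from compound 1 to compound 3 (0.33 log units; beyond the scatter), is modest but beyond the scatter.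

Compound 4 `CC(C)(C)C1=C(C(=O)O)N2C(=O)[C@H]([C@@H](O)c3ccccc3)[C@H]2O1` differs from compound 3 by phenyl in place of tert-butoxycarbonyl on a saturated chain carbon bound to an oxygen on a saturated carbon and a saturated ring carbon. Within the data shown here, no recorded step covers this exact exchange. The step from compound 1 to compound 3 shows that adding tert-butoxycarbonyl at this position raised the number; its removal alone would point the other way. Compound 2 carries phenyl at the same place, though with different stereochemistry, and its value of 0.5 h sits well under compound 1 and compound 3. Together these point to a clear fall in this assay. Compound 4 is therefore expected to give 1 h (range 0.3 h to 3.5 h), a step of an 11-fold lower number from compound 3 to compound 4 (1.03 log units; beyond the scatter) from compound 3.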

Compound 4, half-life: 8.9 h
Estimate against measurement, compound 4: 8.9-fold (0.95 log units) below; measured number outside the range, above it.
By their numbers in this assay, from the lowest: compound 2; then compounds 1, 4 and 3 (each within the scatter of the next, the first and the last beyond it).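

In this assay, phenyl in place of tert-butoxycarbonyl on the saturated chain carbon gives a 1.2-fold lower number from compound 3 to compound 4 (0.08 log units; within the scatter) and so does not separate the two groups in this configuration. Phenyl in place of hydrogen at the same place gives a 1.8-fold higher number from compound 1 to compound 4 (0.25 log units; within the scatter), again with no separation, so the phenyl group alone does not bring a short half-life. The large step, an 18-fold higher number from compound 2 to compound 4 (1.25 log units; beyond the scatter), therefore lies with configuration and not with the phenyl group, due to the following: the fact that compounds 2 and 4 differ only in the configuration as drawn.

As far as these compounds go, the stereocentres at the saturated chain carbon and the saturated ring carbon both differ in this pair, and which of them carries the step stays open. Also open, from the compounds shown here alone, is how an amine or a carboxylic acid on the saturated chain carbon would read in this assay in either configuration.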